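The compounds below may be only part of what the source reports. "The series", "measured", "known", "first", "only" and "open" are said of these compounds alone.

Working notes on the series. Compound 2 `O=C(O)CC/C=C1/C[C@H]2C[C@@H](O)[C@H](/C=N/NC(=O)Nc3cccc(Cl)c3)[C@H]2C1` carries a carboxymethyl group on a saturated chain carbon bound to a double-bonded chain carbon; in a functional assay on a cell-free system (plasma) for agonist activity at thromboxane A2 receptor (Homo sapiens) (a lower number here means a stronger inhibitor, a higher number a weaker inhibitor), compound 2 gives 600 nM. Compound 1 `O=C(O)COC/C=C1/C[C@H]2C[C@@H](O)[C@H](/C=N/NC(=O)Nc3cccc(Cl)c3)[C@H]2C1` differs from it by one change, (carboxymethoxy in place of carboxymethyl on a saturated chain carbon bound to a double-bonded chain carbon), and in this assay compound 1 gives 180 nM. The step of a 3.3-fold lower number from compound 2 to compound 1 (0.52 log units; beyond the scatter) is beyond the usual scatter of this kind of measurement.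

Compound 3 `O=C(O)CC/C=C1\C[C@H]2C[C@@H](O)[C@H](/C=N/NC(=O)Nc3ccc([N+](=O)[O-])cc3)[C@H]2C1` is built on a different core; how the core of compound 3 differs from the core of compound 2 is not broken down here. In this assay compound 3 gives 520 nM, a number within the scatter of that of compound 2, while the gap to compound 1 is beyond the scatter.

Compound 4 `O=C(O)COC/C=C1\C[C@H]2C[C@@H](O)[C@H](/C=N/NC(=O)Nc3ccc([N+](=O)[O-])cc3)[C@H]2C1` is not yet measured. It stands to compound 3 as compound 1 stands to compound 2: the change carboxymethoxy in place of carboxymethyl on a saturated chain carbon bound to a double-bonded chain carbon occurs twice among these compounds, and both place descriptions read the same word for word, so it is the same change, not merely the same kind. For the measured compounds named here, the only measured instance of it is the step from compound 2 to compound 1, and the expectation for compound 4 rests on that single step alone; a second core is not yet tested for this change, so the transfer is uncertain.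

Going by the values given here, on that basis the step of a 3.1-fold lower number from compound 3 to compound 4 (0.49 log units; beyond the scatter) is estimated to be of about the size of the one measured instance of this change. Among the compounds with values here, that instance is a 3.3-fold lower number from compound 2 to compound 1 (0.52 log units; beyond the scatter), and it is the only guide. In this assay compound 4 is therefore expected to give about 170 nM, with a plausible range from 75 nM to 400 nM.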

Compound 4, half-maximal inhibitory concentration: 190 nM
Compound 4: the middle estimate sits 1.1-fold (0.05 log units) below what was measured; measured number inside the range.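

In this assay, the step of a 2.7-fold lower number from compound 3 to compound 4 (0.44 log units; beyond the scatter) points the same way as the earlier step on the other core, so on these two cores carboxymethoxy in place of carboxymethyl on a saturated chain carbon bound to a double-bonded chain carbon carries over in both direction and size: the same change on two cores in this assay, a 3.3-fold lower number (0.52 log units; beyond the scatter) from compound 2 to compound 1 and a 2.7-fold lower number (0.44 log units; beyond the scatter) from compound 3 to compound 4, 1.2-fold (0.09 log units) apart, within the scatter of two such steps

This shows that the change transfers between the core of compound 2 and the core of compound 3, and that the measured step from the first pair was a fair guide for the second. For the compounds shown here, it does not show that the change would behave the same way on any further core, and with only two pairs in a single assay, the agreement gives no reason for the shift and does not reveal which features of the cores, if any, its size depends on.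

Going by these compounds, it remains open whether the lower numbers require the chain oxygen specifically, or whether a sulfur atom or an amine at the same point in the chain would give a similar step. Also open, on these data alone, is how a longer chain carrying the carboxylic acid, or a tetrazole in place of that acid, would behave on either core.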